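Fluoro to Methoxy on the Carbonyl Side: Expecting Compound 3

A few compounds are considered here, and "the series" means these few. Any claim that something is new, unique, unknown or untested is made for them only; others in the source may bear on it.

Compound 1 `CCOc1ccc(C(=O)/C=C/c2ccc(C(F)(F)F)cc2)cc1`: 210 nM
Compound 2 `O=C(/C=C/c1ccc(ON=C(c2ccccc2)c2ccccc2)cc1)c1ccc(F)cc1`: < 50 nM

Of the compounds shown here, two have been measured in an assay on isolated protein for inhibition of Amine oxidase [flavin-containing] B (Homo sapiens); on this read-out higher numbers stand for weaker inhibition and lower numbers for stronger inhibition. Compound 1 gives 210 nM. Compound 2 comes in at < 50 nM, which is a limit of the measurement and not a number, so its true position is known only through (the limit of < 50 nM in this assay, at which 1 of the 2 values shown sits). Among the measured compounds shown here, no two measured compounds differ in a single place, so no measured step is available to lean on. Compound 3 `COc1ccc(C(=O)/C=C/c2ccc(ON=C(c3ccccc3)c3ccccc3)cc2)cc1` has not yet been measured in this assay. It differs from compound 2 by methoxy in place of fluoro on an aromatic carbon. Since only a limit is known for compound 2, the step is expected to be small, in either direction or none beyond the usual scatter. Compound 3 is therefore expected near 40 nM, with a likely range from 10 nM to 150 nM. The expected step amounts to a step that the limit leaves unreadable from compound 2 to compound 3, with a fair chance that this assay again reports only a limit.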

Compound 3, half-maximal inhibitory concentration: < 100 nM
Compound 3 gave a limit, no number; the forecaster's own chance of this, stated with the estimate: 50%; the middle value lies beyond the limit too.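

No step can be read from compound 2 to compound 3 in this assay: each of the two is reported only as a limit, not as a number. The compounds shown leave open how strongly either one inhibits, and whether methoxy in place of fluoro shifts that inhibition at all.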